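Halogen swap on the benzyl ester of the shared core

A few compounds are considered here, and "the series" means these few. Any claim that something is new, unique, unknown or untested is made for them only; others in the source may bear on it.

Compound 1 `COc1ccc(COC(=O)c2cccc(=O)[nH]2)cc1`: 100000 nM in an assay on isolated protein for inhibition of matrix metalloproteinase-9 (Homo sapiens); a lower number here means a stronger inhibitor, a higher number a weaker inhibitor
Compound 2 `O=C(OCc1ccc(F)cc1)c1cccc(=O)[nH]1`: 3000 nM in this assay

Within the data shown here, compound 2 stands at the lowest of the two numbers measured in this assay; its only neighbour is compound 1, and the two are separated by the step of a 33-fold lower number from compound 1 to compound 2 (1.52 log units; beyond the scatter). Among the measured compounds shown here, that step puts fluoro in place of methoxy on an aromatic carbon and is the sole measured step in the set.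

Compound 3 `O=C(OCc1ccc(Cl)cc1)c1cccc(=O)[nH]1` differs from compound 2 by chloro in place of fluoro on an aromatic carbon, on an aromatic carbon of a six-membered aromatic ring of carbon only, para to a large group. For the measured compounds named here, no measured step exchanges one halogen for another, so the step from compound 1 to compound 2, large as it was, gives no direct guide to the size or direction of this change; it shows only what one substituent exchange at that carbon did. Going by the values given here, with no bearing step, a change within the scatter is expected, and the expected step is a 1.5-fold lower number from compound 2 to compound 3 (0.18 log units; within the scatter). Compound 3 is therefore estimated at 2000 nM, with a range from 500 nM to 10000 nM.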

Compound 3, half-maximal inhibitory concentration: 68000 nM
The estimate for compound 3 lay 34-fold (1.53 log units) below the measured number; measured number above the stated range.
By their numbers in this assay, from the lowest: compound 2; then compounds 3 and 1 (each within the scatter of the next).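

In this assay, a 23-fold higher number from compound 2 to compound 3 (1.36 log units; beyond the scatter) shows that one halogen cannot stand in for another at this aromatic carbon, since this exchange alone is beyond the scatter and large. The other new step, a 1.5-fold lower number from compound 1 to compound 3 (0.17 log units; within the scatter), lies within the scatter, so the chloro and methoxy compounds cannot be told apart here, and the earlier gain on moving from methoxy to fluoro is not a general result of replacing methoxy at this carbon. Compound 2 is the strongest inhibitor of the three, with its steps to both others beyond the scatter, and nothing available explains why the fluoro compound stands apart.

Open, from the compounds shown here alone, is whether fluoro is a lone exception at this carbon or one end of a graded series, which a hydrogen, bromo, nitrile or trifluoromethyl group in the same place would begin to settle. Also open, going by these compounds, is whether the gap between fluoro and chloro persists when an amide replaces the ester link on the shared core.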